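The compounds below may be only part of what the source reports. "The series", "measured", "known", "first", "only" and "open" are said of these compounds alone.

Of the compounds shown here, three sharing one core have been measured in a functional assay for inhibition, with Homo sapiens as the target; on this read-out lower numbers stand for stronger inhibition and higher numbers for weaker inhibition. Compound 1 `Fc1cccc(Nc2nccc(-c3ccccn3)n2)c1` gives 1000 nM. Compound 2 `c1ccc(-c2ccnc(Nc3cccc(OCCn4ccnc4)c3)n2)nc1` gives 400 nM, and compound 3 `CC(=O)Nc1cccc(Nc2nccc(-c3ccccn3)n2)c1` gives 300 nM. Among these three numbers compound 3 stands lowest, yet its gap to compound 2 lies within the scatter, so the two cannot be told apart; only compound 1 stands clearly apart, as shown by a 3.3-fold lower number from compound 1 to compound 3 (0.52 log units; beyond the scatter) and a 2.5-fold lower number from compound 1 to compound 2 (0.40 log units; beyond the scatter).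

Compound 4 `NS(=O)(=O)c1cccc(Nc2nccc(-c3ccccn3)n2)c1` differs from compound 3 at that same point: sulfamoyl in place of acetamido on an aromatic carbon. For the measured compounds named here, the steps that bear on this change all sit at that one aromatic carbon. Replacing fluoro by acetamido gave a 3.3-fold lower number from compound 1 to compound 3 (0.52 log units; beyond the scatter), and replacing fluoro by 2-(1H-imidazol-1-yl)ethoxy gave a 2.5-fold lower number from compound 1 to compound 2 (0.40 log units; beyond the scatter), while swapping one of these two groups for the other gave only a 1.3-fold lower number from compound 2 to compound 3 (0.12 log units; within the scatter), a step within the scatter. Sulfamoyl is a further group of the same size by heavy atoms, so the expectation for compound 4 is a step of about no change at the digits printed from compound 3 to compound 4 (within the scatter), not beyond the scatter in either direction. Compound 4 is therefore estimated at 300 nM in this assay, within a range from 100 nM to 900 nM.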

Compound 4, half-maximal inhibitory concentration: 500 nM
Compound 4: middle estimate off by 1.7-fold (0.22 log units), on the low side, within the range that was stated.
By their numbers in this assay, from the lowest: compounds 3, 2, 4 and 1 (each within the scatter of the next, the first and the last beyond it).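

In this assay, sulfamoyl cannot be told apart from the two larger-effect groups at this aromatic carbon: a 1.7-fold higher number from compound 3 to compound 4 (0.22 log units; within the scatter) and a 1.3-fold higher number from compound 2 to compound 4 (0.10 log units; within the scatter) both stay inside the scatter, even though sulfamoyl counts one more hydrogen-bond acceptor and one more double bond than acetamido. What is new is the comparison with fluoro: acetamido and 2-(1H-imidazol-1-yl)ethoxy each stood clearly apart from it, with a 3.3-fold lower number from compound 1 to compound 3 (0.52 log units; beyond the scatter) and a 2.5-fold lower number from compound 1 to compound 2 (0.40 log units; beyond the scatter), whereas a 2.0-fold lower number from compound 1 to compound 4 (0.30 log units; within the scatter) falls within the scatter, so compound 4 cannot be separated from any of the other three compounds, although compound 1 and compound 3 can be separated from each other. Nothing in the available data explains why these groups give such closely spaced numbers at this position.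

Still open is whether any group at this aromatic carbon can move the number well beyond the scatter from compound 3, since the four groups shown span only a narrow range. A simple amine, a carboxylic acid or a sulfamoyl group carrying a longer chain on its nitrogen would test whether this position tolerates almost anything or responds sharply to a particular kind of group.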